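The compounds below may be only part of what the source reports. "The series", "measured", "known", "first", "only" and "open" are said of these compounds alone.

Measured so far:
- compound 1 `CC(C)=CCOc1ccc(C(=O)/C=C/c2ccc(O)cc2)c(O)c1`, in a functional assay on A549 cells (Homo sapiens) for cytotoxicity, read by MTT assay, with a stated time of 72 h (on this read-out lower numbers stand for stronger inhibition and higher numbers for weaker inhibition), compound 1 gives 66000 nM
- compound 2 `COc1cc(/C=C/C=O)cc(OC)c1OCC=C(C)C`, in this assay compound 2 gives 68000 nM
- compound 3 `C=C(C)CCOc1ccc(C(=O)O)cc1OC`, in this assay compound 3 reaches only the limit > 100000 nM, a limit and not a number

Compound 1 holds the lower of the two numbers, with compound 2 within the scatter of it, so the two show no order. The third value is a limit: the limit of > 100000 nM in this assay, at which 1 of the 3 values shown sits.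

Compound 4 `CC(C)=CCOc1ccc(C(=O)/C=C/c2ccccc2)c(O)c1` differs from compound 1 by hydrogen in place of hydroxy on an aromatic carbon. Among the measured compounds shown here, no measured pair of this series shows such a change, so the step size rests on no comparison. The step from compound 1 to compound 4 is expected to be a 1.2-fold higher number from compound 1 to compound 4 (0.08 log units; within the scatter), not beyond the scatter, if anything toward a weaker number. Compound 4 is therefore estimated at 80000 nM, within 35000 nM to 180000 nM.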

Compound 4, half-maximal inhibitory concentration: 54000 nM
Compound 4: middle estimate off by 1.5-fold (0.17 log units), on the high side; the range from low to high includes it.
By their numbers in this assay, from the lowest: compounds 4, 1 and 2 (each within the scatter of the next). At a limit, above all of these: compound 3.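

Among the compounds shown here, the first pair to differ in one place shows that, in this assay, replacing hydroxy with hydrogen on this aromatic carbon, para to a large group, gives a 1.2-fold lower number from compound 1 to compound 4 (0.09 log units; within the scatter). The change from 4-hydroxyphenyl to phenyl therefore leaves the number within the scatter, so this hydroxy is not required for the activity seen at this level. Nothing at hand bears on why this step is so small.

As far as these compounds go, whether an amine, a methoxy or a carboxylic acid at this position would move the number beyond the scatter stays open. From the compounds shown here alone, the contribution of the other hydroxy of the shared core also stays open.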